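Solubility notes: trifluoromethyl to methylcarbamoyl on the pendant ring

The compounds below may be only part of what the source reports. "The series", "measured", "known", "first", "only" and "open" are said of these compounds alone.

The series shares one core, seen in compound 1 `COc1ccc(-c2cc(-c3ccc(C(F)(F)F)cc3)cnc2N)cn1`, compound 2 `COc1ccc(-c2cc(-c3ccc4nccn4c3)cnc2N)cn1` and compound 3 `COc1ccc(-c2cc(-c3ccc4cnn(C)c4c3)cnc2N)cn1`; the three differ only in the aryl group attached to it. In a physicochemical assay for solubility, read by nephelometry, in phosphate buffer, measured as kinetic solubility, at pH 6.5 (a lower number here means a less soluble compound, a higher number a more soluble compound), compound 1 gives 1.6 ug/mL, the lowest of the three numbers. Compound 3 gives 6.3 ug/mL and compound 2 gives 12.5 ug/mL; both gaps to compound 1 lie beyond the usual scatter of this assay, so compound 1 stands apart as the least soluble of the measured set.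

Compound 4 `CNC(=O)c1ccc(-c2cnc(N)c(-c3ccc(OC)nc3)c2)cc1` is not yet measured. It differs from compound 1 in one place: methylcarbamoyl in place of trifluoromethyl on an aromatic carbon. Among the measured compounds shown here, no measured pair in the set isolates this exchange, so the expectation rests on the measured numbers and on the counted change alone. The change is expected to move this assay upward, by a step beyond the scatter, because within the set compound 1 with its trifluoromethyl group gives 1.6 ug/mL while the two compounds without it sit higher. For compound 4 the estimated step from compound 1 is a 5.0-fold higher number from compound 1 to compound 4 (0.70 log units; beyond the scatter). Compound 4 is expected to give about 8 ug/mL, with a likely range from 3 ug/mL to 25 ug/mL.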

Compound 4, solubility: 50 ug/mL
Estimate against measurement, compound 4: 6.3-fold (0.80 log units) below; the whole stated range lies below it.
By their numbers in this assay, from the lowest: compound 1; then compounds 3 and 2 (each within the scatter of the next); then compound 4.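

In this assay, methylcarbamoyl in place of trifluoromethyl on an aromatic carbon, para to a large group, gives a 31-fold higher number from compound 1 to compound 4 (1.49 log units; beyond the scatter), a large step and the only exchange in the series shown as a single-place pair. This position therefore does not treat the two groups alike, even though they have the same heavy-atom count and neither has a ring or a net charge; the entering group differs in carrying a hydrogen-bond donor, a hydrogen-bond acceptor and a double bond outside aromatic rings. No measurement shown here accounts for the size of this step, so these counted differences remain differences only.

From the compounds shown here alone, it remains open which of these counted features goes with the step: a dimethylcarbamoyl group, a primary carboxamide, a nitrile or a carboxylic acid at the same place would help to separate them. Also open, going by these compounds, is whether the step carries over to other compounds on the shared core, as this exchange stands on one pair alone.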